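The source may hold more compounds than are shown below. What is called first, only, known or untested is meant among the compounds shown, and "the series" means these compounds.

Compound 1, `CC(C)COc1ncc(-c2cn(C)c3cc(C(=O)NS(C)(=O)=O)ccc23)cc1Cl`: 216 nm/s
Compound 2, `Cn1cc(-c2ccc(C(F)F)cc2)c2cc(F)c(C(=O)NS(=O)(=O)C3CC3)cc21`: 60 nm/s
Compound 3, `CC(C)Cc1ccc(-c2cn(C)c3cc(C(=O)NS(C)(=O)=O)ccc23)cc1`: "not determined" (no result reported)

Three compounds share a core in this set, and two of them carry a number in an ADME assay for permeability, using PAMPA, at pH 7.4; a lower number here means that the compound crosses the layer more slowly, a higher number that the compound crosses the layer faster. In this assay compound 1 gives 216 nm/s, while compound 2 gives 60 nm/s, the lower of the two numbers; the gap between them lies beyond the usual scatter of the method. For compound 3 the entry in this assay reads "not determined" (no result reported), so it adds nothing to the comparison. Among the compounds with values here, no pair of measured compounds differs in a single place, so the set offers no measured step to lean on.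

Compound 4, `Cn1cc(-c2ccc(C(F)(F)F)cc2)c2cc(F)c(C(=O)NS(=O)(=O)C3CC3)cc21`, is the compound still to be measured. It differs from compound 2 in one place: fluoro in place of hydrogen on a saturated chain carbon bound to an aromatic carbon and two fluorine atoms. The change is small in what it counts, and the account can only weigh it against the value of compound 2 in this assay, 60 nm/s.

The step expected from compound 2 to compound 4 is a 1.3-fold higher number from compound 2 to compound 4 (0.10 log units; within the scatter), a modest rise that may well stay within the scatter. Compound 4 is therefore estimated at 75 nm/s, with a range from 35 nm/s to 150 nm/s.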

Compound 4, apparent permeability: 323 nm/s
The estimate for compound 4 lay 4.3-fold (0.63 log units) below the measured number, outside the stated range (above it).
By their numbers in this assay, from the lowest: compound 2; then compounds 1 and 4 (each within the scatter of the next).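

In this assay, the change from 4-(difluoromethyl)phenyl to 4-(trifluoromethyl)phenyl, a fluoro in place of hydrogen on a saturated chain carbon bound to an aromatic carbon and two fluorine atoms, comes with a 5.4-fold higher number from compound 2 to compound 4 (0.73 log units; beyond the scatter). Within the data shown here, this is the first measured step between two compounds that differ in one place, and it shows what the earlier compounds could not: the number at this position can move well beyond the scatter on a very small edit, one that adds a single heavy atom, no ring, no hydrogen-bond donor or acceptor and no net charge. Nothing available bears on how this change produces the step, so it stands as an observation on this one pair.

The compounds shown leave open what other groups at this position would give, such as a nitrile or a longer chain like pentafluoroethyl. As far as these compounds go, it also remains open whether the same change would give a step of this size with a carboxylic acid where compound 2 and compound 4 carry the cyclopropyl sulfonyl amide.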